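Methyl for isopropyl on the core of compound 2

The compounds below may be only part of what the source reports. "The series", "measured", "known", "first", "only" and "open" are said of these compounds alone.

Two compounds carry measured values in an assay on isolated protein for displacement of a labelled ligand from 5-hydroxytryptamine receptor 6 (Homo sapiens), read by radioligand binding; a higher number here means a weaker inhibitor, a lower number a stronger inhibitor. Compound 1, `CCCCc1ccc(S(=O)(=O)Nc2ccc3c(c2)CCN(C)CC3)cc1`, gives 1.26 nM in this assay. Compound 2, `CC(C)c1cc2c(cc1NS(=O)(=O)c1ccc(-c3ccc(Cl)cc3)cc1)CCN(C)CC2`, gives 12.6 nM in this assay, the higher of the two numbers, and the gap to compound 1 lies beyond the usual scatter. These two compounds differ in more than one place, so only their two values can be set side by side.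

Compound 3, `Cc1cc2c(cc1NS(=O)(=O)c1ccc(-c3ccc(Cl)cc3)cc1)CCN(C)CC2`, has not been measured. It differs from compound 2 in one place: methyl in place of isopropyl on an aromatic carbon. The group sits on an aromatic carbon of a six-membered aromatic ring of carbon only, part of a fused or bridged system of two rings.

Within the data shown here, no measured pair isolates this change, so the expected step rests on the structural change alone. A step of modest size toward a lower number is expected from compound 2 to compound 3, a 2.1-fold lower number from compound 2 to compound 3 (0.32 log units; beyond the scatter), though a result within the scatter would not surprise. For compound 3 the estimate in this assay is 6 nM, with a range from 2 nM to 25 nM.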

Compound 3, inhibition constant: 15.9 nM
Beside the measured number, compound 3's estimate is 2.7-fold (0.42 log units) below it; the range from low to high includes it.
By their numbers in this assay, from the lowest: compound 1; then compounds 2 and 3 (each within the scatter of the next).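

In this assay, methyl in place of isopropyl on an aromatic carbon, ortho to a large group, comes out as a 1.3-fold higher number from compound 2 to compound 3 (0.10 log units; within the scatter). Among these compounds, this is the first comparison that isolates one place, and it shows that the assay does not separate isopropyl, with 3 heavy atoms, from methyl, with 1 heavy atom, at this position on the core of compound 2. No evidence at hand speaks to why these two groups read alike.

Still open, on these data alone, is how the number would respond to a hydrogen, a methoxy group, an amine or a carboxylic acid on this carbon, as isopropyl and methyl are both plain carbon groups with no hydrogen-bond donors or acceptors. Compound 1 differs from compound 2 and compound 3 in more than one place, so its lower number cannot be assigned to this position or to any other single part of the structure.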